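A few compounds are considered here, and "the series" means these few. Any claim that something is new, unique, unknown or untested is made for them only; others in the source may bear on it.

In a functional assay on isolated protein for antagonist activity at C-C chemokine receptor type 9 (Homo sapiens), read by calcium flux, with a stated time of 10 min (on this read-out higher numbers stand for weaker inhibition and lower numbers for stronger inhibition), compound 1 `CC(C)(C)c1ccc(S(=O)(=O)Nc2ccc(Cl)cc2-c2ncccc2CO)cc1` gives 89 nM, the highest of the three numbers shown. Compound 2 `CC(C)(C)c1ccc(S(=O)(=O)Nc2ccc(Cl)cc2-c2nccc(C(N)=O)c2O)cc1` gives 52 nM, and the step of a 1.7-fold lower number from compound 1 to compound 2 (0.23 log units; within the scatter) stays within the scatter. Compound 3 `CC(C)(C)c1ccc(S(=O)(=O)Nc2ccc(Cl)cc2-c2ncncc2N)cc1` gives 3.2 nM; the step of a 28-fold lower number from compound 1 to compound 3 (1.44 log units; beyond the scatter) is large, as is a 16-fold lower number from compound 2 to compound 3 (1.21 log units; beyond the scatter). Compound 4 `CNc1ncc(O)c(-c2cc(Cl)ccc2NS(=O)(=O)c2ccc(C(C)(C)C)cc2)n1` differs from compound 1 by a group of 9 heavy atoms (5 carbon, 3 nitrogen, 1 oxygen; one six-membered aromatic ring with 2 hetero atoms) in place of a group of 8 heavy atoms (6 carbon, 1 nitrogen, 1 oxygen; one six-membered aromatic ring with 1 hetero atom), on an aromatic carbon. Among the compounds with values here, two measured steps bear on this change. The replacement of a six-membered aromatic ring with 1 hetero atom by one with 2 hetero atoms gave a 28-fold lower number from compound 1 to compound 3 (1.44 log units; beyond the scatter), a large move to a lower number. Adding a hydroxy group and a carboxamide to the ring gave a 1.7-fold lower number from compound 1 to compound 2 (0.23 log units; within the scatter), which lay within the scatter. Within the data shown here, since compound 4 carries the ring with 2 hetero atoms, as compound 3 does, a step to a lower number beyond the scatter is expected, a 7.4-fold lower number from compound 1 to compound 4 (0.87 log units; beyond the scatter), though the methylamino and hydroxy groups of compound 4 have no measured counterpart, so the full size of a 28-fold lower number from compound 1 to compound 3 (1.44 log units; beyond the scatter) is not assumed. Compound 4 is therefore estimated at 12 nM, with a range from 3 nM to 45 nM.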

Compound 4, half-maximal inhibitory concentration: 27 nM
For compound 4 the middle estimate is 2.3-fold (0.35 log units) below the measured one; the range from low to high includes it.
By their numbers in this assay, from the lowest: compound 3; then compounds 4, 2 and 1 (each within the scatter of the next, the first and the last beyond it).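

In this assay, the group of compound 4, with its ring of 2 hetero atoms and its methylamino and hydroxy groups, still gives a lower number than the 3-(hydroxymethyl)pyridin-2-yl group (a 3.3-fold lower number from compound 1 to compound 4 (0.52 log units; beyond the scatter)), yet the ring count alone does not set the number, as two different groups on a ring with 2 hetero atoms stand clearly apart (an 8.4-fold higher number from compound 3 to compound 4 (0.93 log units; beyond the scatter)). Compared with the group carrying hydroxy and carboxamide, the group of compound 4 shows no separation (a 1.9-fold lower number from compound 2 to compound 4 (0.28 log units; within the scatter)). Nothing measured here accounts for these differences.

From the compounds shown here alone, the methylamino and hydroxy groups occur only together in compound 4, and their separate shares in these steps remain open. Also open, going by these compounds, is how a dimethylamino group or a carboxylic acid on the same ring would read.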